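A few compounds are considered here, and "the series" means these few. Any claim that something is new, unique, unknown or untested is made for them only; others in the source may bear on it.

Series notes, antiproliferative arm. The shared core is carried unchanged through compounds 1 to 4; only the aryl substitution moves. Compound 1 `C=CC[C@H]1C[C@]2([C@@H](C)Cc3ccc(OC)c(OC)c3)OCOC2=CC1=O` gives 260 nM in a functional assay on NCI-H460 cells (Homo sapiens) for antiproliferative activity, with a stated time of 72 h; a higher number here means a weaker inhibitor, a lower number a stronger inhibitor. Compound 2 `C=CC[C@H]1C[C@]2([C@@H](C)Cc3ccc(OC)cc3)OCOC2=CC1=O` gives 90 nM in this assay, and the step of a 2.9-fold lower number from compound 1 to compound 2 (0.46 log units; beyond the scatter) is a modest change beyond the scatter. Compound 3 `C=CC[C@H]1C[C@]2([C@@H](C)Cc3ccc(OC(C)=O)cc3)OCOC2=CC1=O` is reported in this assay only as a limit, > 20000 nM. The step of an at least 220-fold higher number from compound 2 to compound 3 (2.34 log units; beyond the scatter) is large and runs to the limit (the limit of > 20000 nM in this assay, at which 1 of the 3 values shown sits).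

On the numbers shown, compound 2 has the lowest number; the nearest measured value is that of compound 1, which sits a modest step higher, while compound 3 is a limit rather than a number.

Compound 4 `C=CC[C@H]1C[C@]2([C@@H](C)Cc3ccc(OC)c(C)c3)OCOC2=CC1=O` differs from compound 2 in one place: methyl in place of hydrogen on an aromatic carbon. This is the same aromatic carbon at which compound 1 carries a methoxy group, so the step from compound 1 to compound 2 is the one that bears on it; the step from compound 2 to compound 3, which changes the oxygen substituent itself, does not. The methoxy there cost a modest step; a methyl there is expected to cost about as much or less, so for compound 4 a small rise in this assay, a 1.8-fold higher number from compound 2 to compound 4 (0.25 log units; within the scatter), is expected, and compound 4 is estimated at 160 nM, in the range 60 nM to 450 nM.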

Compound 4, half-maximal inhibitory concentration: 630 nM
Estimate against measurement, compound 4: 3.9-fold (0.60 log units) below; measured number above the stated range.
By their numbers in this assay, from the lowest: compound 2; then compound 1; then compound 4. At a limit, above all of these: compound 3.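

In this assay, the aromatic carbon ortho to a methoxy group proves sensitive to more than one substituent: methyl in place of hydrogen gives a 7.0-fold higher number from compound 2 to compound 4 (0.85 log units; beyond the scatter). Compound 1 had shown a cost only for methoxy at this carbon, whereas the methyl step shows that a single added carbon is enough to raise the number beyond the scatter. Methyl in place of methoxy gives a 2.4-fold higher number from compound 1 to compound 4 (0.38 log units; beyond the scatter), so among the three groups shown at this carbon the order from lowest number is hydrogen, methoxy, methyl, and the number does not rise with the heavy-atom count of the group, since methyl, with 1 heavy atom, stands above methoxy, with 2 heavy atoms.

Nothing measured here bears on why methyl costs more than methoxy at this carbon. It remains open whether fluorine, a hydroxy group or an amine on this aromatic carbon would stay as close to hydrogen as the number of compound 2 or fall with methyl and methoxy, and whether the order of the three groups shown would hold on other aromatic carbons of the ring.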